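This account rests on a few compounds, and the source may have more. Where it says the series, first, only, none or still open, it means among the compounds named here.

Three compounds share one core and differ only in their outer parts. Compound 1 `CCOC(=O)C1=Cc2ccccc2OC1(OCc1cn(-c2ccccc2)nn1)C(F)(F)F` carries a phenyl group on that outer part. In a functional assay on A549 cells (Homo sapiens) for inhibition, read by MTT assay, with a stated time of 24 h (on this read-out higher numbers stand for weaker inhibition and lower numbers for stronger inhibition), compound 1 reaches only a limit of the assay, > 150000 nM, and no number. Compound 2 `CCOC(=O)C1=Cc2ccccc2OC1(OCc1cc(-c2ccc(Cl)cc2)no1)C(F)(F)F` is measured in this assay at 19100 nM. Compound 3 `O=C(O)C1=Cc2ccccc2OC1(OCc1cc(-c2ccc(F)cc2)no1)C(F)(F)F` also returns only a limit in this assay, > 150000 nM. Compound 1 therefore stands at the weak end of what can be read, together with compound 3, since (the limit of > 150000 nM in this assay, at which 2 of the 3 values shown sit); only compound 2 gives a number.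

Compound 4 `CCOC(=O)C1=Cc2ccccc2OC1(OCc1cn(-c2ccc([N+](=O)[O-])cc2)nn1)C(F)(F)F` is the untested neighbour of compound 1. The change is nitro in place of hydrogen on an aromatic carbon; cut one bond further out it reads phenyl to 4-nitrophenyl. For the measured compounds named here, no measured pair in this set shows what such an exchange does, so there is nothing to lean on but the starting point. Starting from a compound that already sits at the limit, the expectation is that the step from compound 1 to compound 4 stays within the usual scatter, with a number no higher from compound 1 to compound 4 (the limit leaves the size open) as the expected change. Compound 4 is thus estimated at 150000 nM, within a range from 40000 nM to 500000 nM, and it may well again be reported only as a limit.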

Compound 4, half-maximal inhibitory concentration: > 150000 nM
Compound 4: no number, only a limit (the forecaster's own chance of this, stated with the estimate: 60%); the middle value sits exactly at the limit.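

The step between compound 1 and compound 4 cannot be read, because both give only a limit and no number in this assay: the limit of > 150000 nM in this assay, at which 3 of the 4 values shown sit.

The compounds shown leave open whether nitro in place of hydrogen on an aromatic carbon changes inhibition at all, and in which direction.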